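An Aryl Exchange on the Shared Core

The source may report more compounds than this note shows. Statements on the series, on what has been measured and on what is new or still open speak of the compounds shown alone.

Of the compounds shown here, three of one series have so far been tested in an assay on CHO cells for displacement of a labelled ligand from adenosine receptor A3 (Homo sapiens), read by scintillation counting, tested at 10 uM; on this read-out lower numbers stand for less inhibition and higher numbers for more inhibition at the one concentration tested (going by the name of the read-out). Compound 1 `Cc1csc(N)c1C(=O)c1ccc(Cl)cc1` gives 1%. Compound 2 `COc1ccc(-c2sc(N)c(C(=O)c3ccc(Cl)cc3)c2C)cc1` differs from compound 1 in one place; compound 2 gives 1%, and the step of no change at the digits printed from compound 1 to compound 2 (within the scatter) thus lies within the scatter of this assay. Compound 3 `CC(C)(C)Cc1c(-c2c(F)cccc2F)sc(N)c1C(=O)c1ccc(Cl)cc1` gives 1% and stands level with compound 1 and compound 2 at the digits reported, its values within the scatter of both.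

Compound 4 `CC(C)c1ccc(-c2sc(N)c(C(=O)c3ccc(Cl)cc3)c2CC(C)(C)C)cc1` is the next variant. Its difference from compound 3 is 4-isopropylphenyl in place of 2,6-difluorophenyl on an aromatic carbon. Going by the values given here, no measured step touches this position; the only step measured, from compound 1 to compound 2, concerns another position and produced no change beyond the scatter. Among the compounds with values here, with all three measured values lying close together and no step showing movement, compound 4 is expected to follow compound 3, with the step of a number 2 percentage points higher from compound 3 to compound 4 (within the scatter) estimated to fall within the scatter. The estimate for compound 4 in this assay is 3%, in a range from 0% to 15%.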

Compound 4, a percentage reported as inhibition, at one concentration (the size of the read-out at that concentration, not a potency): 1%
The estimate for compound 4 lay 2 percentage points above the measured number; measured number inside the range.
By their numbers in this assay, from the lowest: compounds 1, 2, 3 and 4 (each within the scatter of the next).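

In this assay, exchanging one aryl group for another on the aromatic carbon next to the ring sulfur gives no change at the digits printed from compound 3 to compound 4 (within the scatter) as its result, so the swap of 2,6-difluorophenyl for 4-isopropylphenyl, which removes both fluorines and enters a carbon-only group, leaves the number where it was. Going by these compounds alone, this is the first measured replacement of one aryl group by another, and it holds with a neopentyl group on the neighbouring ring atom. Nothing available accounts for this absence of movement.

What the compounds shown leave open is whether any group at this carbon can move the number at all, for instance a basic amine or a carboxylic acid in place of the aryl group. Also open, going by these compounds, is whether a longer chain in place of neopentyl, or a change to the amino group or the (4-chlorophenyl)carbonyl group, would do so.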